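Cytotoxicity notes on a shared-core series

The source may hold more compounds than are shown below. What is called first, only, known or untested is meant among the compounds shown, and "the series" means these compounds.

Three compounds of the series have so far been run in an ADME assay on HEK293 cells (Homo sapiens) for cytotoxicity, read by MTT assay, with a stated time of 36 h; a lower number here means a stronger inhibitor, a higher number a weaker inhibitor. Compound 1 `O=C(c1ccc2c(c1)OCCO2)C1CCN(Cc2coc(-c3ccc(F)cc3)n2)CC1` gives only a limit of the assay, > 150 ug/mL. Compound 2 `O=C(c1ccc2c(c1)OCCO2)C1CCN(Cc2coc(-c3ccc(Br)cc3)n2)CC1` likewise gives only a limit, > 150 ug/mL. Compound 3 `O=C(c1ccc2c(c1)OCCO2)C1CCN(Cc2coc(-c3ccc(C(F)(F)F)cc3)n2)CC1` also gives only a limit, > 150 ug/mL. Compound 3 therefore stands at the limit of > 150 ug/mL in this assay, at which 3 of the 3 values shown sit, and no number for it is known. For the same reason the steps a step that the two limits leave unreadable from compound 1 to compound 2, a step that the two limits leave unreadable from compound 1 to compound 3 and a step that the two limits leave unreadable from compound 2 to compound 3 have no readable size.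

Compound 4 `O=C(c1ccc2c(c1)OCCO2)C1CCN(Cc2coc(-c3ccc(F)c(F)c3)n2)CC1` has not yet been measured. The structural change is 3,4-difluorophenyl in place of 4-(trifluoromethyl)phenyl on an aromatic carbon. The measured steps that bear on it are the three exchanges of a single substituent at the same place among compounds 1, 2 and 3, and none of them has a readable size, since all three sit at the limit of > 150 ug/mL in this assay, at which 3 of the 3 values shown sit. No step beyond the scatter is therefore expected in this assay, and it is expected that compound 4 will again return only a limit rather than a number. The estimate for compound 4 is 200 ug/mL, with a range from 100 ug/mL to 400 ug/mL. The expected step that the limit leaves unreadable from compound 3 to compound 4 is none beyond the scatter.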

Compound 4, half-maximal inhibitory concentration: > 150 ug/mL
Compound 4 was reported as a limit (the forecaster's own chance of this, stated with the estimate: 85%); the middle value lies beyond the limit too.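

In this assay compound 4 gives > 150 ug/mL, again only a limit of the assay. Within the data shown here, no step between compound 4 and compounds 1, 2 or 3 can be read, with all of them at one limit: the limit of > 150 ug/mL in this assay, at which 4 of the 4 values shown sit. The compounds shown leave open whether any substituent exchange on this phenyl ring changes the cytotoxicity in this assay, and how large such a step would be.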